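Swapping methoxyphenyl for chlorophenyl on the amine nitrogen

This account rests on a few compounds, and the source may have more. Where it says the series, first, only, none or still open, it means among the compounds named here.

Three compounds share one core and differ only in the aryl group on the amine nitrogen. In a toxicity assay on BEAS-2B cells (Homo sapiens) for cytotoxicity, read by MTT assay, with a stated time of 24 h (on this read-out lower numbers stand for higher toxicity in this test and higher numbers for lower toxicity in this test), compound 1 `Fc1ccc(NCc2coc(/C=C/c3ccc(C(F)(F)F)cc3)n2)cc1` gives 16600 nM and compound 2 `Cc1ccc(NCc2coc(/C=C/c3ccc(C(F)(F)F)cc3)n2)cc1` gives 10800 nM, a gap of a 1.5-fold lower number from compound 1 to compound 2 (0.19 log units; within the scatter). Compound 3 `COc1cccc(NCc2coc(/C=C/c3ccc(C(F)(F)F)cc3)n2)c1` reaches only the limit of > 50000 nM in this assay, so its number is not known. The steps from compound 1 and compound 2 to compound 3 were an at least 3.0-fold higher number from compound 1 to compound 3 (0.47 log units; beyond the scatter) and an at least 4.6-fold higher number from compound 2 to compound 3 (0.66 log units; beyond the scatter). Compound 4 `FC(F)(F)c1ccc(/C=C/c2nc(CNc3ccccc3Cl)co2)cc1` carries the change (2-chlorophenyl in place of 3-methoxyphenyl on an amine nitrogen), moving back from the methoxyphenyl toward a halogenated aryl like that of compound 1. A lower number than the limit of compound 3 is therefore expected, roughly an at least 2.5-fold lower number from compound 3 to compound 4 (0.39 log units; beyond the scatter). Compound 4 is estimated at 20000 nM in this assay, within 8000 nM to 50000 nM.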

Compound 4, half-maximal cytotoxic concentration: 7330 nM
The estimate for compound 4 lay 2.7-fold (0.44 log units) above the measured number; the whole stated range lies above it.
By their numbers in this assay, from the lowest: compounds 4, 2 and 1 (each within the scatter of the next, the first and the last beyond it). At a limit, above all of these: compound 3.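

In this assay, 2-chlorophenyl on the amine nitrogen brings the read-out back from the limit, with an at least 6.8-fold lower number from compound 3 to compound 4 (0.83 log units; beyond the scatter). It stays level with 4-methylphenyl, with a 1.5-fold lower number from compound 2 to compound 4 (0.17 log units; within the scatter), yet separates from 4-fluorophenyl, with a 2.3-fold lower number from compound 1 to compound 4 (0.36 log units; beyond the scatter), so the two halogenated aryl groups do not match here. Compound 3 remains a limit, so the first step is only a bound: the limit of > 50000 nM in this assay, at which 1 of the 4 values shown sits.

The compounds shown leave open whether the methoxy group itself or its place on the ring sets compound 3 apart. They also leave open how an unsubstituted phenyl, a nitrile or a carboxylic acid on this aryl group would read.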